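The source may hold more compounds than are shown below. What is called first, only, known or untested is meant among the compounds shown, and "the series" means these compounds.

Measured so far:
compound 1, `COc1ccc(Cl)cc1C(=O)NCCC1CCN(S(=O)(=O)NC(=O)NC[C@H]2C[C@@H]3CC[C@@H]2O3)CC1`, 27%
compound 2, `COc1ncccc1C(=O)NCCC1CCN(S(=O)(=O)NC(=O)NC2CCCCC2)CC1`, 33%
compound 3, `COc1ncccc1C(=O)NCCC1CCN(S(=O)(=O)NC(=O)NC[C@@H]2C[C@@H]3CC[C@@H]2O3)CC1`, 34%

In a functional assay on the whole organism (blood) with Rattus norvegicus as the target, with stated times of 24 h and 1 h, at a dose of 5 mg/kg by the intraperitoneal route (on this read-out lower numbers stand for a weaker effect and higher numbers for a stronger effect at the one dose given), compound 3 gives the highest of the three numbers, yet its gaps to compound 2 and compound 1 are within the scatter. Compound 4, `COc1ncccc1C(=O)NCCC1CCN(S(=O)(=O)NC(=O)NC[C@H]2C[C@@H]3CC[C@@H]2O3)CC1`, has not been measured. Its change from compound 3 is the two compounds have the same atoms and bonds and differ only in configuration as drawn: 1 of 3 stereo elements differ; a stereocentre at a saturated ring carbon is drawn S in compound 3 and R in compound 4. For the measured compounds named here, no measured step alters a stereocentre alone; the one step, a number 1 percentage points higher from compound 2 to compound 3 (within the scatter), swaps a ring group and lay within the scatter. Compound 1 carries the same configuration as compound 4 on a different core, and its value in this assay sits within the scatter of compound 3. Compound 4 is therefore expected to move by a number 4 percentage points lower from compound 3 to compound 4 (within the scatter), nothing beyond the scatter, and is estimated at 30%, ranging from 15% to 48%.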

Compound 4, a percentage reported as activity, at one dose (the size of the read-out at that dose, not a potency): 14%
Compound 4: the middle estimate sits 16 percentage points above what was measured; measured number outside the range, below it.
By their numbers in this assay, from the lowest: compound 4; then compounds 1, 2 and 3 (each within the scatter of the next).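

In this assay, changing one stereocentre at a saturated ring carbon gives a number 20 percentage points lower from compound 3 to compound 4 (beyond the scatter), so configuration alone can carry a step beyond the scatter here: the fact that compounds 3 and 4 differ only in the configuration as drawn. The ring-group swap on the amide-type nitrogen, within the scatter for compound 3, now gives a number 19 percentage points lower from compound 2 to compound 4 (beyond the scatter). With this configuration the aryl group also counts, as 2-methoxypyridin-3-yl in place of 5-chloro-2-methoxyphenyl gives a number 13 percentage points lower from compound 1 to compound 4 (beyond the scatter).

Going by these compounds, what the other stereo elements contribute stays open. So does how a straight butyl chain on that nitrogen would compare.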